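The compounds below may be only part of what the source reports. "The series", "measured", "known", "first", "only" and "open" are said of these compounds alone.

Of the compounds shown here, three of a shared core have been measured in a functional assay on SW620/5-FU cells (Homo sapiens) for cytotoxicity, read by MTT assay, with a stated time of 48 h, in the presence of a further agent that is not named here; a higher number here means that more compound is needed for the effect, a lower number that less compound is needed. Compound 1 `Cn1ncc2c(-c3ccccc3)cc(NNC(=O)Nc3cc(Cl)nc(Cl)c3)nc21` gives 76900 nM. Compound 2 `Cn1ncc2c(-c3ccc(F)cc3)cc(NNC(=O)Nc3cc(Cl)cc(Cl)c3)nc21` gives 54300 nM, and compound 3 `COc1ccc(-c2cc(NNC(=O)Nc3cc(Cl)nc(Cl)c3)nc3c2c(C)nn3C)cc1` gives 9700 nM. Compound 2 stands second highest of the three numbers: its gap to compound 1 lies within the scatter, while compound 3 sits beyond the scatter with the lower number.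

Compound 4 `Cn1ncc2c(-c3ccc(F)cc3)cc(NNC(=O)Nc3cc(F)cc(F)c3)nc21` has not been measured. It differs from compound 2 in one place: 3,5-difluorophenyl in place of 3,5-dichlorophenyl on an amide-type nitrogen. Among the measured compounds shown here, no measured pair shows this change. For compound 4 a step from compound 2 is expected that stays within the scatter, leaning toward a higher number, so that a 1.3-fold higher number from compound 2 to compound 4 (0.11 log units; within the scatter) is the estimated step. Compound 4 is therefore expected to give about 70000 nM, with a range from 25000 nM to 200000 nM.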

Compound 4, half-maximal effective concentration: 47400 nM
The estimate for compound 4 lay 1.5-fold (0.17 log units) above the measured number; low and high end bracket the measured number.
By their numbers in this assay, from the lowest: compound 3; then compounds 4, 2 and 1 (each within the scatter of the next).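

In this assay, among the compounds shown here, 3,5-difluorophenyl in place of 3,5-dichlorophenyl on an amide-type nitrogen gives a 1.1-fold lower number from compound 2 to compound 4 (0.06 log units; within the scatter), the first step in this set that changes one place only. At this position, the two halogen pairs therefore cannot be told apart in this assay. No evidence at hand bears on this result.

Whether this position tolerates only halogens stays open, since a phenyl ring carrying an amine or a carboxylic acid does not appear among the compounds shown. On these data alone, whether the same exchange behaves alike on another substituted core also remains open.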